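Furan to thiophene swap on the chloro-biaryl core

The source may report more compounds than this note shows. Statements on the series, on what has been measured and on what is new or still open speak of the compounds shown alone.

Among the measured compounds shown here, compound 2 `Oc1cccc(-c2cc(-c3ccco3)nc(-c3ccccc3Cl)c2)c1` gives 2230 nM in a functional assay on HCT-15 cells (Homo sapiens) for cytotoxicity, read by CCK-8 assay and cell counting, with a stated time of 2 days (a higher number here means a weaker inhibitor, a lower number a stronger inhibitor), the lowest of the three numbers measured so far. Compound 3 `Oc1cccc(-c2cc(-c3cccc(Cl)c3)nc(-c3ccco3)c2)c1` gives 2460 nM in this assay; the gap a 1.1-fold higher number from compound 2 to compound 3 (0.04 log units; within the scatter) is within the scatter, so these two cannot be ordered. Compound 1 `Oc1cccc(-c2cc(-c3ccc(Cl)cc3)nc(-c3ccco3)c2)c1` gives 10200 nM in this assay; the steps of a 4.6-fold lower number from compound 1 to compound 2 (0.66 log units; beyond the scatter) and a 4.1-fold lower number from compound 1 to compound 3 (0.62 log units; beyond the scatter) are the only ones beyond the scatter, and both change the chlorophenyl group while the furan-2-yl group is kept throughout.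

Compound 4 `Oc1cccc(-c2cc(-c3cccs3)nc(-c3ccccc3Cl)c2)c1` differs from compound 2 in one place: thiophen-2-yl in place of furan-2-yl on an aromatic carbon. For the measured compounds named here, none of the measured steps touches the five-membered aromatic ring; all three vary the chlorophenyl group only. Going by the values given here, the series therefore offers nothing to size this step, and the 2-chlorophenyl group shared by compound 2 and compound 4 is the one found with the lowest number so far. Among the compounds with values here, with no step bearing on the change, the expectation is a step from compound 2 to compound 4 of a 1.1-fold lower number from compound 2 to compound 4 (0.05 log units; within the scatter), within the scatter. Compound 4 is estimated at 2000 nM in this assay, with a range of 700 nM to 6000 nM.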

Compound 4, half-maximal inhibitory concentration: 2790 nM
Estimate against measurement, compound 4: 1.4-fold (0.14 log units) below; low and high end bracket the measured number.
By their numbers in this assay, from the lowest: compounds 2, 3 and 4 (each within the scatter of the next); then compound 1.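

Among the compounds shown here, the first step at the five-membered aromatic ring, thiophen-2-yl in place of furan-2-yl next to the ring nitrogen, is within the scatter in this assay (a 1.3-fold higher number from compound 2 to compound 4 (0.10 log units; within the scatter)), so with the 2-chlorophenyl group held constant, this exchange of ring oxygen for ring sulfur leaves no readable difference. The only steps beyond the scatter therefore remain those that change the chlorophenyl group (a 4.6-fold lower number from compound 1 to compound 2 (0.66 log units; beyond the scatter); a 4.1-fold lower number from compound 1 to compound 3 (0.62 log units; beyond the scatter)), while this position has so far shown no readable response to its single exchange, which keeps the heavy-atom, donor and acceptor counts unchanged. No measurement available here accounts for this result.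

Whether the same exchange would also leave no readable difference alongside the 3-chlorophenyl or 4-chlorophenyl group remains open, as the thiophen-2-yl group is shown only with the 2-chlorophenyl group. Also open, on these data alone, is how this position would respond to a group outside these two rings, such as a pyridine ring, an amine or a carboxylic acid, and whether the 3-hydroxyphenyl group, constant throughout, contributes to the numbers.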